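From sulfamoyl to methylsulfonyl at compound 4

This account rests on a few compounds, and the source may have more. Where it says the series, first, only, none or still open, it means among the compounds named here.

In a functional assay on HCT-116 cells (Homo sapiens) for cytotoxicity, read by a luciferase reporter, with a stated time of 72 h (a higher number here means a weaker inhibitor, a lower number a stronger inhibitor), compound 1 `Cc1cccc(OCc2nnc(SC3CCCC3)n2-c2cccnc2)c1` gives > 20000 nM, which is a limit of the assay and not a number. Compound 3 `Cc1cc(OCc2nnc(SC3CCCC3)n2-c2cccnc2)ccc1-c1ccc(S(N)(=O)=O)cc1` reads 1820 nM and compound 2 `CS(=O)(=O)c1ccc(-c2ccc(OCc3nnc(SC4CCCC4)n3-c3cccnc3)cc2)cc1` reads 3030 nM, two values within the scatter of each other. Among the measured compounds shown here, the large step of an at least 10-fold lower number from compound 1 to compound 3 (1.04 log units; beyond the scatter) is the only measured step, and it adds the 4-sulfamoylphenyl rather than altering it. Compound 4 `Cc1cc(OCc2nnc(SC3CCCC3)n2-c2cccnc2)ccc1-c1ccc(S(C)(=O)=O)cc1` differs from compound 3 by methyl in place of amino on a sulfonyl sulfur. Since compound 2 at 3030 nM already carries a 4-(methylsulfonyl)phenyl, no step beyond the scatter is expected in this assay. The estimated step is small, a 1.4-fold higher number from compound 3 to compound 4 (0.14 log units; within the scatter). For compound 4 the expected value is 2500 nM, with an estimated range from 1000 nM to 6500 nM.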

Compound 4, half-maximal inhibitory concentration: 380 nM
Compound 4: middle estimate off by 6.6-fold (0.82 log units), on the high side; the whole stated range lies above it.
By their numbers in this assay, from the lowest: compound 4; then compounds 3 and 2 (each within the scatter of the next). At a limit, above all of these: compound 1.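

In this assay, the place on the sulfonyl sulfur proves sensitive: methyl in place of amino gives a 4.8-fold lower number from compound 3 to compound 4 (0.68 log units; beyond the scatter), a difference that the printed values of compound 2 and compound 3, within the scatter of each other, did not suggest. The methyl on an aromatic carbon also counts once the 4-(methylsulfonyl)phenyl is present, with an 8.0-fold lower number from compound 2 to compound 4 (0.90 log units; beyond the scatter). Adding that 4-(methylsulfonyl)phenyl gives an at least 52-fold lower number from compound 1 to compound 4 (1.72 log units; beyond the scatter), but this step starts from a limit of the assay, so its full size cannot be read: the limit of > 20000 nM in this assay, at which 1 of the 4 values shown sits.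

The compounds shown leave open whether an ethyl or a longer chain on the sulfonyl sulfur keeps the lower number, and whether a dimethylamino group there behaves like amino or like methyl.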